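The source may report more compounds than this note shows. Statements on the series, on what has been measured and on what is new or still open speak of the compounds shown alone.

Measured compounds:
- compound 1, `Cn1nc(-c2ccnc(Nc3ccc(O)cc3)n2)c2ccccc21`: 8910 nM
- compound 2, `CCn1nc(-c2ccnc(Nc3ccc(S(N)(=O)=O)cc3)n2)c2ccccc21`: 2280 nM
- compound 3, `CCn1nc(-c2ccnc(Nc3cccc([N+](=O)[O-])c3)n2)c2ccccc21`: 2310 nM

All three were tested in a functional assay on MCF7 cells (Homo sapiens) for antiproliferative activity, read by MTT assay, with a stated time of 72 h; a higher number here means a weaker inhibitor of growth, a lower number a stronger inhibitor of growth. Compound 3, with its structure `CCn1nc(-c2ccnc(Nc3cccc([N+](=O)[O-])c3)n2)c2ccccc21`, has the second highest of the three numbers. Compound 2 gives 2280 nM, a value within the usual scatter of that of compound 3, so the two cannot be told apart. Compound 1 gives 8910 nM, a higher number that lies beyond the scatter, so compound 1 is a weaker inhibitor of growth than compound 3.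

The next compound, compound 4 with the structure `CCn1nc(-c2ccnc(Nc3ccc(O)cc3)n2)c2ccccc21`, is not yet measured. It differs from compound 3 in one place: 4-hydroxyphenyl in place of 3-nitrophenyl on a nitrogen on an aromatic ring. Compound 4 thereby carries the same 4-hydroxyphenyl group as compound 1 and the same ethyl group as compound 3. Because compound 1 gives 8910 nM, a move towards a higher number is expected for compound 4. The step of a 2.6-fold higher number from compound 3 to compound 4 (0.41 log units; beyond the scatter) is the expected size of this change. Compound 4 is expected to give about 6000 nM in this assay, most likely between 2500 nM and 15000 nM.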

Compound 4, concentration for 50% growth inhibition: 5780 nM
Compound 4: middle estimate off by 1.0-fold (0.02 log units), on the high side; the measured number falls inside the stated range.
By their numbers in this assay, from the lowest: compounds 2 and 3 (each within the scatter of the next); then compounds 4 and 1 (each within the scatter of the next).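

In this assay, 4-hydroxyphenyl in place of 3-nitrophenyl on the nitrogen gives a 2.5-fold higher number from compound 3 to compound 4 (0.40 log units; beyond the scatter) and hydroxy in place of sulfamoyl on the aromatic carbon gives a 2.5-fold higher number from compound 2 to compound 4 (0.40 log units; beyond the scatter) so, with the ethyl group held constant, the hydroxy compound is the weaker inhibitor of growth in both comparisons. The added methyl carbon that turns the methyl group of compound 1 into the ethyl group of compound 4 gives a 1.5-fold lower number from compound 1 to compound 4 (0.19 log units; within the scatter) and this lies within the scatter, so the two chains cannot be told apart when 4-hydroxyphenyl is present. No measurement is available that explains these differences. The step from 3-nitrophenyl changes both the group and its place on the ring, so these two effects remain unseparated. An amine or a carboxylic acid on that ring, or a propyl chain on the ring nitrogen, remains an open case.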